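The source may hold more compounds than are shown below. What is called first, only, known or untested is meant among the compounds shown, and "the series" means these compounds.

Series notes. Compound 1 `CCCCCCCCNC(=O)[C@@H](NC(=O)c1ccccc1)[C@@H](C)O`, compound 2 `CCCCCCCCNC(=O)[C@@H](NC(=O)c1cccs1)[C@@H](C)O` and compound 3 `C/C=C/C=C/C(=O)N[C@H](C(=O)NCCCCCCCC)[C@@H](C)O` share one core that carries an octyl amide on one side and differ only in the acyl group on the other. In a functional assay on SW-620 cells (Homo sapiens) for cytotoxicity, read by MTT assay, with a stated time of 48 h (a higher number here means a weaker inhibitor, a lower number a stronger inhibitor), compound 1 gives 200000 nM, compound 2 gives 136000 nM and compound 3 gives 200000 nM. The three steps among them are all small: a 1.5-fold lower number from compound 1 to compound 2 (0.17 log units; within the scatter), no change at the digits printed from compound 1 to compound 3 (within the scatter) and a 1.5-fold higher number from compound 2 to compound 3 (0.17 log units; within the scatter). Compound 2 holds the lowest of the three numbers, but its nearest neighbour and its furthest neighbour both sit within the scatter, so the three cannot be separated.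

Compound 4 `CCCCCCCCCCCCCCNC(=O)[C@@H](NC(=O)c1cccs1)[C@@H](C)O` keeps the acyl group of compound 2 and alters the chain: hexyl in place of hydrogen on a saturated chain carbon, eight bonds along the chain from an amide-type nitrogen. For the measured compounds named here, none of the measured steps touches this chain; each exchanges the acyl group on the carbonyl carbon with the chain held fixed, so no measured step bears directly on the change from compound 2 to compound 4. With nothing to draw on, the expectation rests on compound 2 alone, and no movement beyond the scatter is predicted in this assay. Compound 4 is therefore estimated at 110000 nM, with a range from 30000 nM to 300000 nM. The expected step is a 1.2-fold lower number from compound 2 to compound 4 (0.09 log units; within the scatter).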

Compound 4, half-maximal inhibitory concentration: 78400 nM
Beside the measured number, compound 4's estimate is 1.4-fold (0.15 log units) above it, and the stated range covers the measured number.
By their numbers in this assay, from the lowest: compounds 4, 2, 1 and 3 (each within the scatter of the next, the first and the last beyond it).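

For the compounds shown here, until now every step exchanged the acyl group with the chain held fixed, so this is the first reading in this assay of a change to the chain itself. Going by these compounds alone, with thiophen-2-yl held in place, hexyl in place of hydrogen on a saturated chain carbon, eight bonds along the chain from an amide-type nitrogen, gives a 1.7-fold lower number from compound 2 to compound 4 (0.24 log units; within the scatter), so in this one pair the added hexyl does not separate compound 4 from compound 2, just as no acyl exchange separated the earlier compounds. No supporting measurement is available to explain this reading.

As far as these compounds go, whether an amine, a carboxylic acid or a longer chain than hexyl at that same saturated chain carbon would move the number beyond the scatter stays open. The hexyl change is also shown only with thiophen-2-yl as the acyl group, so its reading with phenyl or penta-1,3-dien-1-yl in that place remains unknown.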